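The source may report more compounds than this note shows. Statements on the series, on what has been measured and on what is new or still open speak of the compounds shown alone.

Compound 1, `CCCCc1cnc(C(CCCO)Cc2ccc(-c3ccccc3C(=O)O)cc2)[nH]1`, gives 1900 nM in an in vitro functional assay on cells for agonist activity at Bombesin receptor subtype-3 (Homo sapiens), read by luminescence and calcium flux; on this read-out higher numbers stand for an effect only at larger amounts of compound and lower numbers for an effect already at smaller amounts.
Compound 2, `O=C(O)c1ccccc1-c1ccc(CCc2ncc(Cc3cccc(Cl)c3)[nH]2)cc1`, gives 825 nM in this assay.
Compound 3, `CCCCc1cnc(C(CCCC)Cc2ccc(-c3ccccc3C(=O)O)cc2)[nH]1`, gives 2660 nM in this assay.

Among these three, compound 2 has the lowest number in this assay, and its distance from compound 1 as well as from compound 3 is in each case beyond the scatter, so compound 2 is the most potent of the measured set. Compound 4, `Cc1cccc(Cc2cnc(CCc3ccc(-c4ccccc4C(=O)O)cc3)[nH]2)c1`, has not yet been measured. It differs from compound 2 in one place: methyl in place of chloro on an aromatic carbon.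

Among the compounds with values here, only one measured step exists between compounds that differ in a single place, a 1.4-fold higher number from compound 1 to compound 3 (0.15 log units; within the scatter), and it lies within the scatter. That step exchanges a hydroxy for a methyl on a saturated chain carbon, which is a different group at a different place, so it offers no direct guide to what methyl in place of chloro on an aromatic carbon will do. Within the data shown here, no measured step bears on this exchange. Without such guidance, the plain expectation is that the number stays close to where compound 2 already lies. The expected outcome is a step of a 1.1-fold higher number from compound 2 to compound 4 (0.04 log units; within the scatter), within the scatter. Compound 4 is therefore estimated at 900 nM, with a range from 400 nM to 2000 nM.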

Compound 4, half-maximal effective concentration: 4310 nM
Beside the measured number, compound 4's estimate is 4.8-fold (0.68 log units) below it; the whole stated range lies below it.
By their numbers in this assay, from the lowest: compound 2; then compounds 1, 3 and 4 (each within the scatter of the next, the first and the last beyond it).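

Within the data shown here, changing chloro to methyl on the aromatic ring gives a 5.2-fold higher number from compound 2 to compound 4 (0.72 log units; beyond the scatter) in this assay and is the first single-place change in this set to go beyond the scatter. The only earlier step, a 1.4-fold higher number from compound 1 to compound 3 (0.15 log units; within the scatter), stayed within it and concerned a saturated chain carbon, so this aromatic carbon, meta to a large group, is the first place shown to respond to a one-group exchange. The response is notable for so small an edit, as chloro and methyl match in heavy-atom count, hydrogen-bond donors and acceptors, and net charge, and differ in that count only by element, so those simple tallies do not anticipate the step, and nothing available here gives a reason for it.

From the compounds shown here alone, only chloro and methyl are compared at this place, so it remains open whether chloro is especially favourable or methyl especially unfavourable, and plain hydrogen, fluoro, bromo, methoxy or trifluoromethyl there could help to separate the two. Going by these compounds, it is also open whether the same exchange would give a step of similar size on another core, such as that of compound 1.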